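Swapping bromo for methoxy at the edge of compound 1

This account rests on a few compounds, and the source may have more. Where it says the series, first, only, none or still open, it means among the compounds named here.

Compound 1 `O=C(CSc1nnnn1-c1ccccc1)N/N=c1/scc(-c2ccc(Br)cc2)n1-c1ccccc1` is the starting point. In an ADME assay on NIH3T3 cells (Mus musculus) for cytotoxicity, read by MTT assay, with a stated time of 24 h (on this read-out lower numbers stand for stronger inhibition and higher numbers for weaker inhibition), compound 1 gives 433 ug/mL, the highest of the two numbers recorded. Compound 2 `Cc1nnc(SCC(=O)N/N=c2/scc(-c3ccc([N+](=O)[O-])cc3)n2-c2ccccc2)s1` gives 177 ug/mL in this assay, a lower number that lies beyond the scatter of the method. Compound 3 `N#Cc1ccc(-c2cs/c(=N/NC(=O)CSc3ncccn3)n2-c2ccccc2)cc1` returns only a limit in this assay, < 3.9 ug/mL, which is not a number but the edge of what the assay can report (the limit of < 3.9 ug/mL in this assay, at which 1 of the 3 values shown sits).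

Compound 4 `COc1ccc(-c2cs/c(=N/NC(=O)CSc3nnnn3-c3ccccc3)n2-c2ccccc2)cc1` has not yet been tested. It differs from compound 1 in one place (methoxy in place of bromo on an aromatic carbon), methoxy in place of bromo on an aromatic carbon, para to a large group. Among the compounds with values here, no measured pair in this set shows the effect of such a change, so the size of the step rests on judgement alone. The expected step from compound 1 to compound 4 is a 1.2-fold lower number from compound 1 to compound 4 (0.09 log units; within the scatter), none beyond the scatter in either direction. Compound 4 is therefore estimated at 350 ug/mL, with a likely range from 120 ug/mL to 800 ug/mL.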

Compound 4, half-maximal inhibitory concentration: 11.7 ug/mL
Beside the measured number, compound 4's estimate is 30-fold (1.48 log units) above it; measured number outside the range, below it.
By their numbers in this assay, from the lowest: compound 4; then compound 2; then compound 1. At a limit, below all of these: compound 3.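

Within the data shown here, compounds 1 and 4 form the first pair here that differs in one place, so the effect of this position can now be read on its own. On the six-membered aromatic ring of carbon only, para to a large group, replacing bromo with methoxy gives a 37-fold lower number from compound 1 to compound 4 (1.57 log units; beyond the scatter) in this assay, which shows that this edge of the molecule can by itself shift the number by a large step while the rest of the structure stays the same. Compound 3 stands at a limit of the assay and not at a number: the limit of < 3.9 ug/mL in this assay, at which 1 of the 4 values shown sits.

This one pair cannot separate what the loss of bromo contributes from what the entry of methoxy contributes. On these data alone, how a hydrogen, a hydroxyl or a dimethylamino group would read at this place remains open, as does whether the same swap would give a step of similar size with the other sulfur-linked rings.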